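Pyridine nitrogen position on the ring-amine arm

A few compounds are considered here, and "the series" means these few. Any claim that something is new, unique, unknown or untested is made for them only; others in the source may bear on it.

Among the measured compounds shown here, compound 1 `Clc1cc(Cl)cc(CO[C@H]2CCCN(Cc3cccnc3)[C@H]2c2ccccc2)c1` stands as the weakest of the three measured members: in an assay on isolated protein for activation of cGMP-dependent protein kinase 1 (Homo sapiens), read by ADP-Glo, with stated times of 120 min and 40 min (a higher number here means that more compound is needed for the effect, a lower number that less compound is needed), compound 1 gives 112000 nM. Compound 2 `OC[C@@H](O[C@H]1CCCN(Cc2ccccc2Cc2nnco2)[C@H]1c1ccccc1)c1cc(Cl)cc(Cl)c1` gives 3700 nM in this assay, and compound 3 `O=C(O)c1ccc2c(CN3CCC[C@H](O[C@H](CO)c4cc(Cl)cc(Cl)c4)[C@@H]3c3ccccc3)c[nH]c2c1` gives 22000 nM. For the measured compounds named here, the only measured one-place change is a 5.9-fold higher number from compound 2 to compound 3 (0.77 log units; beyond the scatter), which swaps the whole arm on the ring amine and so says nothing about shifting a nitrogen within an otherwise unchanged pyridine. Compound 4 `Clc1cc(Cl)cc(CO[C@H]2CCCN(Cc3ccccn3)[C@H]2c2ccccc2)c1` differs from compound 1 only in pyridin-2-yl in place of pyridin-3-yl on a saturated chain carbon bound to an amine nitrogen in a ring. Going by the values given here, no measured pair bears on this kind of change, so there is no basis to expect a step in either direction beyond the scatter; the hydrogen-bond count and atom count are unchanged. Compound 4 is therefore expected to give 110000 nM in this assay, within a range of 40000 nM to 300000 nM. The expected step of a 1.0-fold lower number from compound 1 to compound 4 (0.01 log units; within the scatter) is thus estimated to stay inside the usual scatter.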

Compound 4, half-maximal effective concentration: > 200000 nM
Compound 4: only a limit was reported (the forecaster's own chance of this, stated with the estimate: 25%); middle value at least 1.8-fold (0.25 log units) away from the limit.
By their numbers in this assay, from the lowest: compound 2; then compound 3; then compound 1. At a limit, above all of these: compound 4.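

Compound 4 gives no number in this assay, only a limit of the assay: the limit of > 200000 nM in this assay, at which 1 of the 4 values shown sits.

Pyridin-2-yl in place of pyridin-3-yl on a saturated chain carbon bound to an amine nitrogen in a ring gives an at least 1.7-fold higher number from compound 1 to compound 4 (0.25 log units; that floor lies within the scatter) and, as this is only a floor, the true size of the step remains unknown. Unlike the earlier step, which swapped the whole arm on the ring amine, this pair isolates the pyridine nitrogen position and shows no sign that pyridin-2-yl lowers the number from the value of compound 1.

The compounds shown leave open how a pyridin-4-yl arm would read on the same core. Also open, on these data alone, is whether either pyridine arm would give a lower number on the core of compound 2, which would make a measured comparison possible.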